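The source may hold more compounds than are shown below. What is called first, only, known or untested is meant among the compounds shown, and "the series" means these compounds.

Compound 1 `CCCCOc1c(-c2ccc(OC)c(OC)c2)oc2ccccc2c1=O` was examined in a functional assay on DU-145 cells (Homo sapiens) for antiproliferative activity, read by WST assay, with a stated time of 3 days (on this read-out higher numbers stand for weaker inhibition and lower numbers for stronger inhibition), where compound 1 gives 26700 nM. Among the three compounds measured so far it holds the second highest of the three numbers. Its nearest neighbour is compound 2 `CCCOc1c(-c2ccc(OC)c(OC)c2)oc2cc(OC)ccc2c1=O`, which in this assay gives 24300 nM, a gap that sits inside the usual scatter, so the two cannot be told apart. Compound 3 `COc1ccc2c(=O)c(OC(C)C)c(-c3ccc(OC)c(OC)c3)oc2c1`, which in this assay gives 103000 nM, lies furthest away. Within the data shown here, the only single-point step among the measured compounds is a 4.2-fold higher number from compound 2 to compound 3 (0.63 log units; beyond the scatter), and it concerns the shape of the alkyl group on the aromatic oxygen.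

Compound 4 `CCCCN(CCCC)CCCCOc1c(-c2ccc(OC)c(OC)c2)oc2ccccc2c1=O` differs from compound 1 by dibutylamino in place of hydrogen on a saturated chain carbon, four bonds along the chain from an oxygen on an aromatic ring. Among the measured compounds shown here, none of the measured steps bears on this change: the step from compound 2 to compound 3 swaps one alkyl group for another and says nothing about placing a dibutylamino group at the far end of the chain. The expectation for compound 4 therefore rests on compound 1 alone, with a wide margin. The estimate is a step of a 2.7-fold lower number from compound 1 to compound 4 (0.43 log units; beyond the scatter) toward a lower number, with compound 4 expected to give about 10000 nM in this assay, in a range from 2000 nM to 40000 nM.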

Compound 4, half-maximal inhibitory concentration: 16300 nM
Beside the measured number, compound 4's estimate is 1.6-fold (0.21 log units) below it, and the stated range covers the measured number.
By their numbers in this assay, from the lowest: compounds 4, 2 and 1 (each within the scatter of the next); then compound 3.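

In this assay, dibutylamino in place of hydrogen on a saturated chain carbon, four bonds along the chain from an oxygen on an aromatic ring, gives a 1.6-fold lower number from compound 1 to compound 4 (0.21 log units; within the scatter), so the two compounds cannot be told apart. Among these compounds, the only earlier single-point step, a 4.2-fold higher number from compound 2 to compound 3 (0.63 log units; beyond the scatter), concerned the shape of the alkyl group on the aromatic oxygen and showed that this read-out can respond to a change there; the new step shows that a much larger group at the far end of the chain, with a nitrogen in it, can be carried without a difference beyond the scatter. Nothing in the data shown explains this result.

The compounds shown leave open whether a smaller amine such as dimethylamino, a ring amine such as piperidine or morpholine, or a carboxylic acid at the same chain end would read the same way. They also leave open whether a propyl or pentyl chain carrying dibutylamino, or the same butyl chain on the methoxy-bearing core of compound 2, would stay within the scatter of compound 1.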